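The source may report more compounds than this note shows. Statements on the series, on what has been measured and on what is new or still open speak of the compounds shown alone.

Compound 1 `COc1ccc(S(=O)(=O)c2nc3ccccc3nc2Nc2ccc(N)cc2)cc1` gives 9640 nM in a functional assay on PC-3 cells (Homo sapiens) for cytotoxicity, read by MTT assay, with a stated time of 72 h; a lower number here means a stronger inhibitor, a higher number a weaker inhibitor.
Compound 2 `COc1ccc(S(=O)(=O)c2nc3ccccc3nc2Nc2cccc(N)c2)cc1` gives 8600 nM.
Compound 3 `Nc1ccc(Nc2nc3ccccc3nc2S(=O)(=O)c2ccc(Br)cc2)cc1` gives 2330 nM.

Compound 1 and compound 2 differ in one place, (3-aminophenyl in place of 4-aminophenyl on a nitrogen on an aromatic ring), and the step of a 1.1-fold lower number from compound 1 to compound 2 (0.05 log units; within the scatter) is too small to tell the two values apart. Compound 3 differs from compound 1 in a different place, (bromo in place of methoxy on an aromatic carbon), and the step of a 4.1-fold lower number from compound 1 to compound 3 (0.62 log units; beyond the scatter) leaves compound 3 with the lowest number of the three, with compound 2 and compound 1 both clearly higher.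

Compound 4 `Nc1cccc(Nc2nc3ccccc3nc2S(=O)(=O)c2ccc(Br)cc2)c1` has not yet been measured. It differs from compound 3 by 3-aminophenyl in place of 4-aminophenyl on a nitrogen on an aromatic ring, which is the same change that turns compound 1 into compound 2, made at the same place. For the measured compounds named here, the step of a 1.1-fold lower number from compound 1 to compound 2 (0.05 log units; within the scatter) is the only guide available for what that change does. Compound 4 is therefore expected to sit close to compound 3, with an estimated step of a 1.1-fold lower number from compound 3 to compound 4 (0.05 log units; within the scatter). The estimate for compound 4 is 2100 nM, expected to fall between 1000 nM and 4500 nM. This rests on a single pair of compounds, so the expectation is loose.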

Compound 4, half-maximal inhibitory concentration: 9010 nM
Beside the measured number, compound 4's estimate is 4.3-fold (0.63 log units) below it, outside the stated range (above it).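

The shift from 4-aminophenyl to 3-aminophenyl does not carry over from one core to the other in this assay. With bromo in the molecule it gives a 3.9-fold higher number from compound 3 to compound 4 (0.59 log units; beyond the scatter), and the two steps for this shift clearly disagree: the same change on two cores in this assay, a 1.1-fold lower number (0.05 log units; within the scatter) from compound 1 to compound 2 and a 3.9-fold higher number (0.59 log units; beyond the scatter) from compound 3 to compound 4, 4.3-fold (0.64 log units) apart, beyond the scatter of two such steps
The swap of methoxy for bromo depends on its partner in the same way, since with 3-aminophenyl it gives a 1.0-fold higher number from compound 2 to compound 4 (0.02 log units; within the scatter), unlike its step with 4-aminophenyl: the same change on two cores in this assay, a 4.1-fold lower number (0.62 log units; beyond the scatter) from compound 1 to compound 3 and a 1.0-fold higher number (0.02 log units; within the scatter) from compound 2 to compound 4, 4.3-fold (0.64 log units) apart, beyond the scatter of two such steps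
So the two changes cannot be treated as adding up independently here, and of these four compounds only compound 3 stands apart, but the data do not show why, nor whether this holds beyond these two pairs.

From the compounds shown here alone, it remains open whether the low number of compound 3 is particular to bromo or would also appear with chloro or methyl in its place. Going by these compounds, it is equally open whether a hydroxyl group in place of the amine would show the same dependence on where it sits.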